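Methylpyrazolyl in place of pyrazolyl on an imidazoline aryl amine

This account rests on a few compounds, and the source may have more. Where it says the series, first, only, none or still open, it means among the compounds named here.

Measured compounds:
compound 1, `CCn1ccc(-c2ccccc2NCC2=NCCN2)n1`, 0%
compound 2, `c1ccc(-c2cn[nH]c2)c(NCC2=NCCN2)c1`, 62%

In a functional assay with Alpha-1D adrenergic receptor (Homo sapiens) as the target, read by calcium flux (on this read-out lower numbers stand for smaller maximal responses and higher numbers for larger maximal responses), compound 2 gives 62%, the higher of the two numbers recorded; its nearest neighbour, compound 1, gives 0%, a gap beyond the scatter. Compound 3, `Cn1ccc(-c2ccccc2NCC2=NCCN2)n1`, has not yet been measured. It differs from compound 2 in one place: 1-methyl-1H-pyrazol-3-yl in place of 1H-pyrazol-4-yl on an aromatic carbon. Among the measured compounds shown here, no step between measured compounds is recorded, so the size of this change rests on expectation only. Because compound 1, which likewise carries no 1H-pyrazol-4-yl, gives 0%, a large downward step is expected, a number 47 percentage points lower from compound 2 to compound 3 (beyond the scatter), with the maximal response of compound 3 estimated at 15%, between 0% and 45%.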

Compound 3, largest response reached (reported as maximal response), in percent of the reference or control that the assay uses: 29%
Compound 3: middle estimate off by 14 percentage points, on the low side, within the range that was stated.
By their numbers in this assay, from the lowest: compound 1; then compound 3; then compound 2.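

In this assay, the step from the unsubstituted ring to the methylated one is a number 33 percentage points lower from compound 2 to compound 3 (beyond the scatter), so 1-methyl-1H-pyrazol-3-yl does not match 1H-pyrazol-4-yl on this aromatic carbon, though it keeps part of the response. The size of the nitrogen substituent also counts at this position: hydrogen in place of methyl on the saturated chain carbon bound to the aromatic nitrogen gives a number 29 percentage points higher from compound 1 to compound 3 (beyond the scatter). No measurement shown accounts for either step.

The compounds shown leave open how much of the first step comes from the methyl on the ring nitrogen and how much from the changed ring attachment, a question that 1H-pyrazol-3-yl or 1-methyl-1H-pyrazol-4-yl would separate. Also open, as far as these compounds go, is whether the response falls further or recovers with a hydroxyethyl chain on that nitrogen.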